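Aryl urea series: iodo-methoxyphenyl amine replacing methylmethoxyphenyl amine

A few compounds are considered here, and "the series" means these few. Any claim that something is new, unique, unknown or untested is made for them only; others in the source may bear on it.

Compound 1 `COc1cc(NC(=O)Nc2cc(Nc3ccc(OC)c(C)c3)ncn2)cc(OC)c1` gives 19.7% in a functional assay on NCI-H1581 cells (Homo sapiens) for inhibition, read by MTT assay, with a stated time of 48 h, tested at 10 uM (on this read-out higher numbers stand for more inhibition at the one concentration tested (going by the name of the read-out) and lower numbers for less inhibition), and is the lowest of the three numbers in hand. Compound 3 `O=C(Nc1cc(Nc2ccc(F)c(Cl)c2)ncn1)Nc1c(Cl)cccc1Cl` gives 67% and compound 2 `COc1ccc(C(F)(F)F)cc1Nc1cc(NC(=O)Nc2c(Cl)cccc2Cl)ncn1` gives 69.1%; both sit beyond the scatter above compound 1, but both differ from compound 1 at more than one place, so no single change can be held responsible.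

Compound 4 `COc1cc(NC(=O)Nc2cc(Nc3cc(I)ccc3OC)ncn2)cc(OC)c1` keeps the urea side of compound 1 and alters only the amine side: 5-iodo-2-methoxyphenyl in place of 4-methoxy-3-methylphenyl on a nitrogen on an aromatic ring. Among the measured compounds shown here, no measured pair isolates this change. The methoxy group of the entering ring is shared with the amine ring of compound 2, but compound 2 also carries a different urea aryl, so the numbers for compound 2 cannot be read as a guide to this one change.

For compound 4 the expected step of a number 12.3 percentage points higher from compound 1 to compound 4 (beyond the scatter) is a modest rise, not clearly beyond the scatter. Compound 4 is accordingly estimated at 32%, with a range from 10% to 62%.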

Compound 4, a percentage reported as inhibition, at one concentration (the size of the read-out at that concentration, not a potency): 59%
For compound 4 the middle estimate is 27 percentage points below the measured one; low and high end bracket the measured number.
By their numbers in this assay, from the lowest: compound 1; then compounds 4, 3 and 2 (each within the scatter of the next, the first and the last beyond it).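

Among the compounds shown here, with the urea side held fixed in this assay, 5-iodo-2-methoxyphenyl in place of 4-methoxy-3-methylphenyl on a nitrogen on an aromatic ring gives a number 39.3 percentage points higher from compound 1 to compound 4 (beyond the scatter), and this is the first change that can be read alone. The amine side is therefore a position where the read-out responds strongly, and the low number of compound 1 cannot be attributed to its urea side alone. Nothing on hand bears on the reason for this step.

The entering ring differs from the leaving ring in both the iodine and the placing of the methoxy group, and the contribution of each remains unresolved. Also open, going by these compounds, are whether a chloro, a bromo, an amine or a carboxylic acid could stand in place of the iodine, and whether the same amine change holds with a 2,6-dichlorophenyl urea.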